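From nitro to methoxymethoxy: what compound 4 may show

A few compounds are considered here, and "the series" means these few. Any claim that something is new, unique, unknown or untested is made for them only; others in the source may bear on it.

Compound 1, `CC(C)=CCC/C(C)=C/CCC1=C[C@H](c2ccccc2[N+](=O)[O-])OC1=O`, measured in an assay on microsomes from liver for inhibition of 3-hydroxy-3-methylglutaryl-coenzyme A reductase (Sus scrofa), read by colorimetric assay; on this read-out lower numbers stand for stronger inhibition and higher numbers for weaker inhibition: compound 1 gives 18900 nM.
Compound 2, `COc1ccc([C@H]2C=C(CC/C=C(\C)CCC=C(C)C)C(=O)O2)cc1`: compound 2 gives 6210 nM.
Compound 3, `COc1ccc(OC)c([C@H]2C=C(CC/C=C(\C)CCC=C(C)C)C(=O)O2)c1`: compound 3 gives 13200 nM.

Among these three, compound 1 stands at the highest number in this assay. Its nearest neighbour is compound 3, whose number lies within the usual scatter of compound 1, so no order between these two can be claimed. Compound 2 sits at a lower number than compound 1 by a margin beyond the scatter.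

Compound 4, `COCOc1ccccc1[C@H]1C=C(CC/C=C(\C)CCC=C(C)C)C(=O)O1`, has not yet been measured. It differs from compound 1 in one place: methoxymethoxy in place of nitro on an aromatic carbon. Among the compounds with values here, no pair of measured compounds shows this same change, so there is no measured step to lean on. Compound 2 and compound 3, which carry different groups on the same aromatic ring, sit at or near the number of compound 1, and none of them reaches a low number.

On that basis a modest step toward a lower number is expected from compound 1 to compound 4, of about a 1.7-fold lower number from compound 1 to compound 4 (0.24 log units; within the scatter), with a real chance that it remains within the scatter. Compound 4 is estimated at 11000 nM in this assay, with a likely range from 3500 nM to 35000 nM.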

Compound 4, half-maximal inhibitory concentration: 8900 nM
For compound 4 the middle estimate is 1.2-fold (0.09 log units) above the measured one; the range from low to high includes it.
By their numbers in this assay, from the lowest: compounds 2, 4, 3 and 1 (each within the scatter of the next, the first and the last beyond it).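

In this assay, within the data shown here, the replacement of nitro by methoxymethoxy on an aromatic carbon, ortho to a large group, gives the first measured step at this place: a 2.1-fold lower number from compound 1 to compound 4 (0.33 log units; beyond the scatter), a modest change that nonetheless lies beyond the usual scatter. It shows that this position can take a different group without the number rising, and that the read-out responds, if only slightly, to what sits there. As counted, the two groups match in having no ring, no hydrogen-bond donors, no net charge and the same number of hydrogen-bond acceptors, yet nitro carries a double bond outside aromatic rings and methoxymethoxy does not, and nothing shown ties the step to this or any other feature of either group.

From the compounds shown here alone, whether a simple hydroxyl or an amine in this same place would move the number further, in either direction, remains open. Among these compounds, with only one pair showing this change, it also cannot be said whether the same replacement would give a similar step in another compound built on the shared core.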